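This account rests on a few compounds, and the source may have more. Where it says the series, first, only, none or still open, it means among the compounds named here.

Of the compounds shown here, three sharing one core have been measured in an ADME assay on a cell-free system (plasma, Homo sapiens) for protein binding. Compound 1 (`Cc1ccc([C@@H](C)Oc2cc3oc(=O)n(CCC(=O)O)c3cc2Cl)nc1`) gives 97.8%, compound 2 (`CCc1cc2oc(=O)n(CCC(=O)O)c2cc1Cl`) gives 98.7%, and compound 3 (`O=C(O)CCn1c(=O)oc2cc(OCC3CC3)c(Cl)cc21`) gives 96%. Compound 3 and compound 1 lie within the usual scatter of each other, while compound 3 leaves clearly more drug unbound than compound 2.

Compound 4 (`CCOc1cc2oc(=O)n(CCC(=O)O)c2cc1Cl`) has not yet been measured. It differs from compound 3 in one place: methyl in place of cyclopropyl on a saturated chain carbon bound to an oxygen on an aromatic ring. Put another way, cyclopropylmethoxy becomes ethoxy, with methyl in place of cyclopropyl on a saturated chain carbon bound to an oxygen on an aromatic ring.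

Among the measured compounds shown here, only one measured step bears on this change: a 3.1-fold higher unbound fraction from compound 2 to compound 3 (0.49 log units; beyond the scatter), with cyclopropylmethoxy in place of ethyl on an aromatic carbon. For the measured compounds named here, that step was modest, and no measured compound carries ethoxy, so the evidence is thin. The new change keeps the oxygen and replaces only the cyclopropyl, so a smaller step is expected, with no clear direction. The expected change is a 1.1-fold lower unbound fraction from compound 3 to compound 4 (0.06 log units; within the scatter), which would not exceed the scatter. For compound 4 the estimate is 96.5%, with an expected range from 93% to 98.5%.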

Compound 4, plasma protein binding: 95.8%
Beside the measured number, compound 4's estimate is 1.2-fold (0.08 log units) (unbound fraction) below it; measured number inside the range.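

In this assay the result is a 1.1-fold higher unbound fraction from compound 3 to compound 4 (0.02 log units; within the scatter) and so cyclopropyl and methyl cannot be told apart at this saturated chain carbon. Replacing the larger 5-methylpyridin-2-yl group with hydrogen gives a 1.9-fold higher unbound fraction from compound 1 to compound 4 (0.28 log units; within the scatter) and this also stays within the scatter. Among the compounds shown here, the one new step beyond the scatter is ethoxy in place of ethyl on an aromatic carbon, at a 3.2-fold higher unbound fraction from compound 2 to compound 4 (0.51 log units; beyond the scatter) and it suggests that the oxygen on the aromatic ring matters more here than what sits further out on the chain, since compound 1, compound 3 and compound 4 carry that oxygen and compound 2 lacks it.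

On these data alone, whether an amine in place of that oxygen, or a longer chain on it, would fit this picture stays open. Nothing available gives a reason for any of these steps.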